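The source may report more compounds than this note shows. Statements on the series, on what has been measured and on what is new or still open speak of the compounds shown alone.

Two compounds of a shared core have been examined in a functional assay on HL-60 cells (Homo sapiens) for cytotoxicity (on this read-out lower numbers stand for stronger inhibition and higher numbers for weaker inhibition), so far. Compound 1 `CC1(C)CCC(C)(C)c2cc(/C=C/c3ccc(N)cc3)ccc21` gives 18000 nM in this assay. Compound 2 `CC1(C)CCC(C)(C)c2cc(/C=C/c3cccc(N)c3)ccc21` gives 20000 nM. Among the compounds with values here, the only step between them, a 1.1-fold higher number from compound 1 to compound 2 (0.05 log units; within the scatter), came with a 3-aminophenyl in place of a 4-aminophenyl on a double-bonded chain carbon bound to a double-bonded chain carbon. On the numbers at hand, compound 1 stands lowest of the two, and its nearest neighbour, compound 2, lies within the scatter of it.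

Compound 3 `CC1(C)CCC(C)(C)c2cc(/C=C\c3ccc(N)cc3)ccc21` is not yet measured in this assay. From compound 1 to compound 3 the change is the two compounds have the same atoms and bonds and differ only in configuration as drawn: 1 of 1 stereo elements differ; a double bond is drawn E in compound 1 and Z in compound 3; nothing leaves and nothing enters, and only the geometry of the double bond as drawn is altered. Within the data shown here, no measured step concerns such a change: the one step on record, from compound 1 to compound 2, moved a group on the ring and stayed within the scatter, so it offers no direct guide. The estimate for compound 3 therefore rests on compound 1 alone and is set near it, with a broad range, as a 1.4-fold higher number from compound 1 to compound 3 (0.14 log units; within the scatter). Compound 3 is expected to give about 25000 nM, within 8000 nM to 80000 nM.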

Compound 3, half-maximal inhibitory concentration: 18000 nM
Estimate against measurement, compound 3: 1.4-fold (0.14 log units) above; measured number inside the range.
By their numbers in this assay, from the lowest: compounds 1, 3 and 2 (each within the scatter of the next).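

Within the data shown here, the earlier pair spoke only to the swap of 4-aminophenyl for 3-aminophenyl on the ring, whereas this pair is the first to test the double bond itself: in this assay, redrawing it from E to Z gives no change at the digits printed from compound 1 to compound 3 (within the scatter). Across the three compounds shown, then, neither the geometry of the double bond nor the swap of 4-aminophenyl for 3-aminophenyl moves the number beyond the scatter, and this holds only for these compounds, at this weak level of the read-out. The comparison bears on that single feature and on nothing else in the structure: the fact that compounds 1 and 3 differ only in the configuration as drawn

The compounds shown leave open whether the Z double bond would behave in the same way with 3-aminophenyl in place of 4-aminophenyl, and whether a carboxylic acid, a hydroxyl or an amide in place of the amine would take the number beyond the scatter. They also leave open what a single bond or a triple bond in place of the double bond would do in this assay.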